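Swapping the sulfonyl pyridyl group: from compound 3 to compound 4

The source may report more compounds than this note shows. Statements on the series, on what has been measured and on what is new or still open speak of the compounds shown alone.

Measured compounds:
compound 1 `CNCc1cn(S(=O)(=O)c2ncccc2C)c(-c2cccnc2F)c1F` gives 54%
compound 2 `CNCc1cn(S(=O)(=O)c2cccc(C)n2)c(-c2cccnc2F)c1F` gives 91%
compound 3 `CNCc1cn(S(=O)(=O)c2cccnc2Cl)c(-c2cccnc2F)c1F` gives "not determined" (no result reported)

All three share one core; they differ only in the aryl group attached to the sulfonyl sulfur. In a functional assay on the whole organism (strain Jcl:Sprague-Dawley) for inhibition, with Rattus norvegicus as the target, with stated times of 3 min and 3 h, at a dose of 1 mg/kg by the intravenous route (on this read-out higher numbers stand for more inhibition at the one dose given (going by the name of the read-out) and lower numbers for less inhibition), compound 1 gives 54%, and compound 2 gives 91%. Going by the values given here, the one measured step, a number 37 percentage points higher from compound 1 to compound 2 (beyond the scatter), moves the methyl from one position of the pyridin-2-yl ring to another, and it is large. Compound 3 was tested, but this assay reported no number for it, so there is no starting value to build on.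

Compound 4 `CNCc1cn(S(=O)(=O)c2ccc(C)nc2)c(-c2cccnc2F)c1F` arises from compound 3 by the change (6-methylpyridin-3-yl in place of 2-chloropyridin-3-yl on a sulfonyl sulfur). Among the compounds with values here, no measured step matches this change: the only step available exchanges two methylpyridin-2-yl groups, whereas here a chlorine leaves and a methyl enters on a pyridin-3-yl ring. That step shows only that this assay can respond strongly to small changes on the sulfonyl aryl group, so the expectation for compound 4 is wide and rests on the span between compound 1 and compound 2. Compound 4 is expected to give about 70%, within a range from 35% to 95%.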

Compound 4, a percentage reported as inhibition, in the whole organism at one dose (the size of the read-out at that dose, not a potency): 97%
For compound 4 the middle estimate is 27 percentage points below the measured one; the whole stated range lies below it.
By their numbers in this assay, from the lowest: compound 1; then compounds 2 and 4 (each within the scatter of the next).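

In this assay, the 6-methylpyridin-3-yl group on the sulfonyl sulfur performs on a par with the 6-methylpyridin-2-yl group, giving a number 6 percentage points higher from compound 2 to compound 4 (within the scatter), so among these two groups the change of ring attachment makes no readable difference. The same group set against 3-methylpyridin-2-yl gives a number 43 percentage points higher from compound 1 to compound 4 (beyond the scatter), which shows that the large gain seen earlier is not confined to a single group: two different 6-methylpyridyl groups now sit well clear of the 3-methylpyridin-2-yl group of compound 1. Nothing available explains why these groups behave as they do.

On these data alone, the steps that start from compound 3 cannot be read, as it has no number, so what the swap of chlorine for methyl does on a pyridin-3-yl ring remains unknown, and a reading at one dose cannot tell whether compound 2 and compound 4 differ in potency. Also open, as far as these compounds go, is whether the ring nitrogen is needed at all, which a plain phenyl group would test, and whether an amine or a carboxylic acid could take the place of the methyl on the pyridin-3-yl ring.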